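The source may report more compounds than this note shows. Statements on the series, on what has been measured and on what is new or still open speak of the compounds shown alone.

Of the compounds shown here, three built on one shared core have been tested in a functional assay on MCF7 cells (Homo sapiens) for antiproliferative activity, read by MTT assay, with a stated time of 72 h; a lower number here means a stronger inhibitor, a higher number a weaker inhibitor. Compound 1 `CCCSc1nc(N/N=C/c2cccs2)c2nnn(Cc3ccccc3)c2n1` reaches only the edge of what the assay can read, giving > 64000 nM, which is a limit and not a number. Compound 2 `CCCSc1nc(N/N=C(\C)c2ccccc2O)c2nnn(Cc3ccc(Cl)cc3)c2n1` gives 42600 nM in this assay, and compound 3 `C#CCSc1nc(N/N=C/c2c(O)ccc3ccccc23)c2nnn(Cc3ccccc3)c2n1` gives 8970 nM. Compound 1 thus stands at the point where no number could be read at all, and the limit of > 64000 nM in this assay, at which 1 of the 3 values shown sits, shows that it is the only one of the three to sit there.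

The next compound, compound 4 `CCCSc1nc(N/N=C/c2ccc(Br)cc2)c2nnn(Cc3ccccc3)c2n1`, differs from compound 1 in one place: 4-bromophenyl in place of thiophen-2-yl on a carbon with a double bond to nitrogen. Among the compounds with values here, nothing among the measured compounds shows what this exchange does, since no pair of them differs in only that way. With compound 1 giving only a limit, the true size of the step to compound 4 cannot be fixed from the data. The step that is expected is an at least 1.6-fold lower number from compound 1 to compound 4 (0.20 log units; that floor lies within the scatter), a modest gain that may not leave the scatter. Compound 4 is therefore expected to give about 40000 nM in this assay, within a range from 12000 nM to 130000 nM, with a real chance that it too reports only a limit.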

Compound 4, half-maximal inhibitory concentration: > 64000 nM
Compound 4 was reported as a limit; the forecaster's own chance of this, stated with the estimate: 45%; at least 1.6-fold (0.20 log units) between middle value and limit.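

Compound 1 and compound 4 both report only a limit and not a number, so no step can be read for 4-bromophenyl in place of thiophen-2-yl: the limit of > 64000 nM in this assay, at which 2 of the 4 values shown sit.

The compounds shown leave open whether this exchange changes activity at all in this assay, and how much weaker than the limit compound 1 and compound 4 truly are.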